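The source may hold more compounds than are shown below. What is called first, only, known or untested is meant among the compounds shown, and "the series" means these compounds.

Working notes on the series.

Compound 1 `COc1ccc2c(/C=C/C(=O)c3cc(N)c(OC)c(OC)c3)cn(C)c2c1` is the reference point; in a functional assay on HeLa cells (Homo sapiens) for antiproliferative activity, read by MTT assay, with a stated time of 48 h (a higher number here means a weaker inhibitor, a lower number a stronger inhibitor), compound 1 gives 356 nM. Compound 2 `COc1ccc2c(/C=C/C(=O)c3cc(OC)c(OC)c([N+](=O)[O-])c3)cn(C)c2c1` carries a nitro group where compound 1 has the amino group, and in this assay compound 2 gives 951 nM; the step of a 2.7-fold higher number from compound 1 to compound 2 (0.43 log units; beyond the scatter) is the only one in the set at this aromatic carbon. Compound 3 `COc1ccc2c(/C=C/C(=O)c3cc(OC)c(OC)c([N+](=O)[O-])c3)c[nH]c2c1` differs from compound 2 only at the aromatic nitrogen, and in this assay compound 3 gives 850 nM; the step of a 1.1-fold lower number from compound 2 to compound 3 (0.05 log units; within the scatter) shows that this exchange is not resolved by the assay. Compound 3 thus stands second highest of the three numbers, within the scatter of compound 2 and beyond it from compound 1.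

Compound 4 `COc1ccc2c(/C=C/C(=O)c3cc(OC)c(OC)c([Se]C)c3)c[nH]c2c1` is not yet measured. The change from compound 3 is a group of 2 heavy atoms (1 carbon, 1 selenium; no ring) in place of a group of 3 heavy atoms (1 nitrogen, 2 oxygen; no ring), on an aromatic carbon. The step of a 2.7-fold higher number from compound 1 to compound 2 (0.43 log units; beyond the scatter) is the only measured step at this position and was modest; no measured step involves the entering group itself, so its direction is not shown. On that basis the step of a 1.4-fold lower number from compound 3 to compound 4 (0.15 log units; within the scatter) is expected to be small, with the range kept wide. For compound 4 in this assay the estimated value is 600 nM, between 250 nM and 1500 nM.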

Compound 4, half-maximal inhibitory concentration: 104 nM
Beside the measured number, compound 4's estimate is 5.8-fold (0.76 log units) above it; measured number outside the range, below it.
By their numbers in this assay, from the lowest: compound 4; then compound 1; then compounds 3 and 2 (each within the scatter of the next).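

At this aromatic carbon, ortho to a methoxy group, the exchange in this assay gives an 8.2-fold lower number from compound 3 to compound 4 (0.91 log units; beyond the scatter), which shows that a group without a common name, holding 1 carbon and 1 selenium, can replace nitro with a change well beyond the scatter. Together with a 2.7-fold higher number from compound 1 to compound 2 (0.43 log units; beyond the scatter), it makes nitro the group with the higher number in both measured steps at this position, whether amino or the selenium group stands opposite it in the pair. Nothing measured here accounts for the size of the new step.

Open, going by these compounds, is whether the selenium atom itself matters, or whether a methylthio group or a longer chain on selenium would give a similar number at this carbon. Also open, on these data alone, is how the selenium group compares directly with amino on an otherwise identical core.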